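This account rests on a few compounds, and the source may have more. Where it says the series, first, only, none or still open, it means among the compounds named here.

In a functional assay on MCF7 cells (Homo sapiens) for antiproliferative activity, read by MTT assay, with a stated time of 72 h (on this read-out lower numbers stand for stronger inhibition and higher numbers for weaker inhibition), compound 1 (`O=S(=O)(Oc1ccccc1Cl)C1CC2OC1C(c1ccc(/C=C/c3cc(O)cc(O)c3)cc1)=C2c1ccc(O)cc1`) gives 40400 nM and compound 2 (`O=S(=O)(Oc1ccc(-c2ccccc2)cc1)C1CC2OC1C(c1ccc(/C=C/c3cc(O)cc(O)c3)cc1)=C2c1ccc(O)cc1`) gives 7800 nM, so compound 2 has the lower number of the two and the stronger inhibition. Compound 3 (`O=S(=O)(Oc1cccc(Br)c1)C1CC2OC1C(c1ccc(/C=C/c3cc(O)cc(O)c3)cc1)=C2c1ccc(O)cc1`) keeps the shared core and has 3-bromophenyl in place of 4-phenylphenyl on an oxygen whose other neighbour is the sulfonyl sulfur: 3-bromophenyl in place of 4-phenylphenyl on an oxygen. Within the data shown here, one measured step bears on this change: a 5.2-fold lower number from compound 1 to compound 2 (0.71 log units; beyond the scatter), a modest step beyond the scatter, with 4-phenylphenyl in place of 2-chlorophenyl at the same place. Like the 2-chlorophenyl of compound 1, the 3-bromophenyl has one six-membered aromatic ring of carbon only. A partial return is therefore expected in this assay, with an estimated step of a 2.6-fold higher number from compound 2 to compound 3 (0.41 log units; beyond the scatter), toward a higher number but smaller than the measured step. For compound 3, the estimated value is 20000 nM, with a range of 7000 nM to 50000 nM.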

Compound 3, half-maximal inhibitory concentration: 19800 nM
For compound 3 the middle estimate is 1.0-fold (0.00 log units) above the measured one, within the range that was stated.
By their numbers in this assay, from the lowest: compound 2; then compound 3; then compound 1.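

In this assay, the place on the oxygen whose other neighbour is the sulfonyl sulfur responds to a second change: 3-bromophenyl in place of 4-phenylphenyl gives a 2.5-fold higher number from compound 2 to compound 3 (0.40 log units; beyond the scatter), so the two-ring group keeps the lowest number of the three. The count of aromatic rings does not settle the number on its own, as the two one-ring groups also differ, with a 2.0-fold lower number from compound 1 to compound 3 (0.31 log units; beyond the scatter). Nothing available explains why these groups differ.

Since 3-bromophenyl and 2-chlorophenyl differ in both the halogen and its place on the ring, the compounds shown cannot separate those two changes. As far as these compounds go, it also stays open how this position would respond to a ring carrying an amine or a carboxylic acid, or to a plain alkyl chain in place of the ring.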